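Triazole side-chain variation on a shared butenolide-type core

A few compounds are considered here, and "the series" means these few. Any claim that something is new, unique, unknown or untested is made for them only; others in the source may bear on it.

Measured so far:
compound 1, `O=C1O[C@H]([C@@H](O)Cn2cc(-c3cc(C(F)(F)F)cc(C(F)(F)F)c3)nn2)C(OCc2ccccc2)=C1OCc1ccccc1` — 28900 nM
compound 2, `CCCCc1cn(C[C@H](O)[C@H]2OC(=O)C(OCc3ccccc3)=C2OCc2ccccc2)nn1` — 28600 nM

In a functional assay on A549 cells (Homo sapiens) for antiproliferative activity, read by MTT assay, with a stated time of 72 h (on this read-out lower numbers stand for stronger inhibition and higher numbers for weaker inhibition), compound 1 gives 28900 nM and compound 2 gives 28600 nM; the two numbers lie within the scatter of each other, so neither can be placed ahead of the other. Compound 3, `O=C1O[C@H]([C@@H](O)Cn2cc(CCCCl)nn2)C(OCc2ccccc2)=C1OCc1ccccc1`, has not been measured. It differs from compound 2 by chloro in place of methyl on a saturated chain carbon, three bonds along the chain from an aromatic carbon. Among the compounds with values here, with only two measured compounds and no step between them, the expectation for this change is no shift beyond the scatter in this assay; the step from compound 2 to compound 3 is estimated at a 1.1-fold lower number from compound 2 to compound 3 (0.04 log units; within the scatter). Compound 3 is therefore expected to give 26000 nM, in the range 10000 nM to 65000 nM.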

Compound 3, half-maximal inhibitory concentration: 29000 nM
Compound 3: the middle estimate sits 1.1-fold (0.05 log units) below what was measured, within the range that was stated.
By their numbers in this assay, from the lowest: compounds 2, 1 and 3 (each within the scatter of the next).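

In this assay, within the data shown here, the change from butyl to 3-chloropropyl gives a 1.0-fold higher number from compound 2 to compound 3 (0.01 log units; within the scatter) and so offers the first single-place reading: at this saturated chain carbon, chloro in place of methyl produces no shift beyond the scatter. This reading covers one substitution at one place. No evidence bearing on this result is available.

Still open, as far as these compounds go, is whether an amine, a carboxylic acid or a longer chain at this place would separate from compound 2 beyond the scatter. Changes to the shared core also remain open.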